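A few compounds are considered here, and "the series" means these few. Any claim that something is new, unique, unknown or untested is made for them only; others in the source may bear on it.

In a functional assay on NCI-H460 cells (Homo sapiens) for inhibition, read by CCK-8 assay, with a stated time of 72 h, tested at 10 uM (a higher number here means more inhibition of growth at the concentration tested, a lower number less inhibition of growth), compound 1 `CN(C)C(=O)c1cc2cnc(Nc3ccc(NC(=O)C4(C(=O)Nc5ccc(Cl)cc5)CC4)cc3)nc2n1C1CCCC1` gives 95.7% while compound 2 `CN(C)C(=O)c1cc2cnc(Nc3ccc(NC(=O)C4(C(=O)Nc5cccc(Cl)c5)CC4)cc3)nc2n1C1CCCC1` gives 101% and compound 3 `CN(C)C(=O)c1cc2cnc(Nc3ccc(NC(=O)C4(C(=O)Nc5ccc(O)cc5)CC4)cc3)nc2n1C1CCCC1` gives 104% and so sits within the usual scatter of both others. Compound 4 `CN(C)C(=O)c1cc2cnc(Nc3ccc(NC(=O)C4(C(=O)Nc5ccccc5)CC4)cc3)nc2n1C1CCCC1` differs from compound 3 by one change (hydrogen in place of hydroxy on an aromatic carbon): hydrogen in place of hydroxy on an aromatic carbon. The measured steps that bear on this alter the same ring: hydroxy in place of chloro (a number 8.3 percentage points higher from compound 1 to compound 3 (within the scatter)), 4-hydroxyphenyl in place of 3-chlorophenyl (a number 3 percentage points higher from compound 2 to compound 3 (within the scatter)) and 3-chlorophenyl in place of 4-chlorophenyl (a number 5.3 percentage points higher from compound 1 to compound 2 (within the scatter)). For the measured compounds named here, all stayed within the scatter, although no compound with a plain phenyl there has been measured. No step beyond the scatter is therefore expected in this assay for this change. The estimated step is small (a number 6 percentage points lower from compound 3 to compound 4 (within the scatter)). Compound 4 is expected at 98% with an estimated range of 85% to 108% around that figure.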

Compound 4, percent growth inhibition at one concentration: 95.9%
Estimate against measurement, compound 4: 2.1 percentage points above, within the range that was stated.
By their numbers in this assay, from the lowest: compounds 1, 4, 2 and 3 (each within the scatter of the next).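

In this assay, for the compounds shown here, the plain phenyl gives the first reading with no substituent on this ring: taking away the hydroxy group gives (a number 8.1 percentage points lower from compound 3 to compound 4 (within the scatter)), and taking away chloro gives (a number 5.1 percentage points lower from compound 2 to compound 4 (within the scatter)) and (a number 0.2 percentage points higher from compound 1 to compound 4 (within the scatter)). Among these compounds, then, hydroxy, chloro and hydrogen on this aromatic carbon cannot be told apart at this single concentration. Nothing available explains this result.

From the compounds shown here alone, whether an amine, a carboxylic acid or a longer chain at this place would also leave the number within the scatter stays open. So does whether these four compounds would separate at lower concentrations.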